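The compounds below may be only part of what the source reports. "The series", "measured", "known", "first", "only" and "open" are said of these compounds alone.

Compound 3, with the structure `Cc1ccc2[nH]c(=O)c(CN(Cc3ccc(OCC(=O)O)cc3)Cc3ccc(C(C)(C)C)cc3)cc2c1`, is one of three compounds examined in a toxicity assay on MDCK cells (Canis lupus familiaris) for cytotoxicity, read by crystal violet staining, with a stated time of 48 h (a lower number here means that less compound is tolerated, a higher number that more compound is tolerated), and all three stand only at limits of that assay, so no number places compound 3 against the others. In this assay compound 3 reaches only a limit, > 10000 nM, and that is the limit of > 10000 nM in this assay, at which 1 of the 3 values shown sits. Compound 1, with the structure `CCCCC(c1cc2ccc(C)cc2[nH]c1=O)N(Cc1ccc(F)cc1)Cc1ccc(C(C)C)cc1`, likewise gives only a limit in this assay, > 33000 nM, which is the limit of > 33000 nM in this assay, at which 1 of the 3 values shown sits. Compound 2, with the structure `CCc1ccc2[nH]c(=O)c(CN(Cc3ccc(F)cc3)Cc3cccc4ccccc34)cc2c1`, also gives only a limit in this assay, > 5000 nM, which is the limit of > 5000 nM in this assay, at which 1 of the 3 values shown sits. For the measured compounds named here, no step between measured compounds can therefore be sized here.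

Compound 4, with the structure `Cc1ccc2[nH]c(=O)c(CN(Cc3ccc(C(N)=O)cc3)Cc3ccc(C(C)(C)C)cc3)cc2c1`, is not yet measured. It differs from compound 3 by a single change: carbamoyl in place of carboxymethoxy on an aromatic carbon. With every value shown sitting at a limit, there is nothing to mark a direction for this step, and the expectation is a step in this assay that stays within the scatter, so that compound 4 is expected to come out as a limit as well. The estimated step from compound 3 to compound 4 in this assay is a step that the limit leaves unreadable from compound 3 to compound 4. Compound 4 is expected to show about 20000 nM, in a range from 5000 nM to 100000 nM.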

Compound 4, half-maximal cytotoxic concentration: > 5000 nM
Compound 4 ended at the assay's limit; the forecaster's own chance of this, stated with the estimate: 80%; the middle value does not contradict the limit.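

Compound 3 and compound 4 both stand only at limits in this assay, so no size or direction can be read for the step between them. The compounds shown leave open at what concentration any of them becomes toxic to these cells, and whether carbamoyl in place of carboxymethoxy changes the concentration tolerated at all.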